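Methoxy removal from compound 2: working notes

This account rests on a few compounds, and the source may have more. Where it says the series, first, only, none or still open, it means among the compounds named here.

In a functional assay on SK-N-SH cells (Homo sapiens) for cytotoxicity, read by MTT assay, with a stated time of 48 h (on this read-out lower numbers stand for stronger inhibition and higher numbers for weaker inhibition), compound 1 `COc1cc(/C=C/c2ccc(C)cc2)c(-c2ccccc2)c(OC)c1OC` gives 31000 nM. Compound 2 `C=C(c1ccc(OC)cc1)c1cc(OC)c(OC)c(OC)c1-c1ccccc1` gives 31000 nM, level with compound 1 within the scatter. Compound 3 `C=C(c1ccccc1)c1cc(OC)c(OC)c(OC)c1-c1ccccc1` carries hydrogen in place of methoxy on an aromatic carbon, para to a large group, the 4-methoxyphenyl of compound 2 becoming phenyl: hydrogen in place of methoxy on an aromatic carbon. For the measured compounds named here, no measured pair shows this change, so the expectation rests on compound 2 at 31000 nM alone. The expected change in this assay is a 1.0-fold lower number from compound 2 to compound 3 (0.01 log units; within the scatter), with no shift beyond the scatter in either direction. For compound 3 the estimated value is 30000 nM, with an expected range of 12000 nM to 70000 nM.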

Compound 3, half-maximal inhibitory concentration: 34000 nM
For compound 3 the middle estimate is 1.1-fold (0.05 log units) below the measured one, and the stated range covers the measured number.
By their numbers in this assay, from the lowest: compounds 1, 2 and 3 (each within the scatter of the next).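

In this assay hydrogen in place of methoxy on an aromatic carbon, para to a large group, gives a 1.1-fold higher number from compound 2 to compound 3 (0.04 log units; within the scatter) and so the methoxy of the 4-methoxyphenyl is not needed to hold the number at this level. 1-Phenylethenyl in place of 2-(4-methylphenyl)ethenyl gives a 1.1-fold higher number from compound 1 to compound 3 (0.04 log units; within the scatter) and likewise separates nothing in this assay. No supporting data bear on why the numbers stay level.

Still open, as far as these compounds go, is whether another group at this carbon, such as an amine or a carboxylic acid, would move the number beyond the scatter. A longer alkoxy chain there is equally untested in the compounds shown.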